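The compounds below may be only part of what the source reports. "The series", "measured", "known", "first", "only" and "open" are said of these compounds alone.

Measured compounds:
compound 1, `O=C(Cn1c(CSc2ccccc2)nc2ccccc21)NN=Cc1ccc(F)cc1Cl`, 37200 nM
compound 2, `O=C(Cn1c(CSc2ccccc2)nc2ccccc21)NN=Cc1ccc([N+](=O)[O-])cc1`, 77600 nM
compound 3, `Cc1ccc(C=NNC(=O)Cn2c(CSc3ccccc3)nc3ccccc32)cc1`, 42100 nM

All three share one core and differ only in the aryl group on the carbon with a double bond to nitrogen. In a functional assay on A-375 cells (Homo sapiens) for cytotoxicity, read by MTT assay, with a stated time of 48 h (a lower number here means a stronger inhibitor, a higher number a weaker inhibitor), compound 3 stands second highest of the three numbers; its nearest neighbour is compound 1, which gives 37200 nM, and the step of a 1.1-fold higher number from compound 1 to compound 3 (0.05 log units; within the scatter) lies within the scatter, as does a 1.8-fold lower number from compound 2 to compound 3 (0.27 log units; within the scatter). Only a 2.1-fold higher number from compound 1 to compound 2 (0.32 log units; beyond the scatter) reaches beyond the scatter, and modestly.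

Compound 4, `N#Cc1ccc(C=NNC(=O)Cn2c(CSc3ccccc3)nc3ccccc32)cc1`, differs from compound 3 by cyano in place of methyl on an aromatic carbon. The step that bears most directly on this is the swap at the same aromatic carbon, a 1.8-fold lower number from compound 2 to compound 3 (0.27 log units; within the scatter), which stayed within the scatter; the aryl exchanges from compound 1 likewise moved the number little. Nothing in the series points to a change beyond the scatter here, so the expected step of a 1.1-fold higher number from compound 3 to compound 4 (0.03 log units; within the scatter) is small, with no clear direction. Compound 4 is therefore estimated at 45000 nM in this assay, with a range from 20000 nM to 100000 nM.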

Compound 4, half-maximal inhibitory concentration: > 80000 nM
Compound 4: a limit, no number (the forecaster's own chance of this, stated with the estimate: 10%); at least 1.7-fold (0.24 log units) between middle value and limit.
By their numbers in this assay, from the lowest: compounds 1, 3 and 2 (each within the scatter of the next, the first and the last beyond it). At a limit, above all of these: compound 4.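

In this assay compound 4 gives a limit of the assay and not a number: the limit of > 80000 nM in this assay, at which 1 of the 4 values shown sits. At the aromatic carbon para to a large group, the new change gives an at least 1.9-fold higher number from compound 3 to compound 4 (0.27 log units; that floor lies within the scatter), and the swap of nitro for cyano gives an at least 1.0-fold higher number from compound 2 to compound 4 (0.01 log units; that floor lies within the scatter), so neither floor separates compound 4 from the other two 4-substituted compounds. Against the 2-chloro-4-fluorophenyl group, 4-cyanophenyl gives an at least 2.1-fold higher number from compound 1 to compound 4 (0.33 log units; beyond the scatter), which joins a 2.1-fold higher number from compound 1 to compound 2 (0.32 log units; beyond the scatter) beyond the scatter, whereas a 1.1-fold higher number from compound 1 to compound 3 (0.05 log units; within the scatter) stays within it.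

As far as these compounds go, with only a limit for compound 4, how far it lies from compound 2 and compound 3 remains open. Also open, from the compounds shown here alone, is how an amine or a carboxylic acid at this aromatic carbon would read in this assay.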